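The source may report more compounds than this note shows. Statements on the series, on what has been measured and on what is new or still open speak of the compounds shown alone.

Measured so far, in a functional assay on MDA-MB-435 cells (Homo sapiens) for cytotoxicity, read by MTT assay, with a stated time of 72 h; a lower number here means a stronger inhibitor, a higher number a weaker inhibitor:
compound 1, `O=C(NCc1ccc(F)cc1)c1nc(Br)c2cccnc2c1NCc1ccccc1`, > 20000 nM;
compound 2, `CS(=O)(=O)Oc1c(C(=O)NCc2ccc(F)cc2)nc(Br)c2cccnc12`, > 20000 nM;
compound 3, `N[C@H]1CC[C@H](Nc2c(C(=O)NCc3ccc(Cl)cc3Cl)nc(Br)c3cccnc23)CC1`, 5800 nM.

Compound 1 is read only as a limit of this assay, not as a number. Among the measured compounds shown here, the one measured step from it, a step that the two limits leave unreadable from compound 1 to compound 2, also ends at a limit, so its size is not readable; both rest at the limit of > 20000 nM in this assay, at which 2 of the 3 values shown sit. Compound 4, `N[C@H]1CC[C@H](Nc2c(C(=O)NCc3ccc(F)cc3)nc(Br)c3cccnc23)CC1`, differs from compound 1 by 4-aminocyclohexyl in place of benzyl on a nitrogen on an aromatic ring. For the measured compounds named here, no measured step covers this change, but compound 3 carries the same (4-aminocyclohexyl)amino group and gives a number in this assay. Compound 4 is therefore expected to move past the limit, by about an at least 2.5-fold lower number from compound 1 to compound 4 (0.39 log units; beyond the scatter), to an estimated 8000 nM, within 2500 nM to 25000 nM.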

Compound 4, half-maximal inhibitory concentration: 6000 nM
Compound 4: the middle estimate sits 1.3-fold (0.12 log units) above what was measured, within the range that was stated.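

In this assay, (4-aminocyclohexyl)amino in place of benzylamino gives an at least 3.3-fold lower number from compound 1 to compound 4 (0.52 log units; beyond the scatter), and in place of (methylsulfonyl)oxy it gives an at least 3.3-fold lower number from compound 2 to compound 4 (0.52 log units; beyond the scatter). Both steps start from a limit, so they show only a minimum size: the limit of > 20000 nM in this assay, at which 2 of the 4 values shown sit.

With (4-aminocyclohexyl)amino in place, 4-fluorophenyl in place of 2,4-dichlorophenyl gives a 1.0-fold higher number from compound 3 to compound 4 (0.01 log units; within the scatter), so this change leaves the number unmoved.

The compounds shown leave open whether the amine on the cyclohexyl ring matters. A plain cyclohexyl, a hydroxyl in place of that amine, or a 2-aminoethyl chain would test this.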